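Aryl swap on the ring nitrogen of the thiazolidinone series

The compounds below may be only part of what the source reports. "The series", "measured", "known", "first", "only" and "open" are said of these compounds alone.

Compound 3 `O=C(NCCCCc1ccccc1)c1cccc(C2SCC(=O)N2c2nccs2)c1` carries 1,3-thiazol-2-yl on the amide-type nitrogen of the shared core. In a functional assay on HOS-TE85 cells (Homo sapiens) for inhibition, read by CCK-8 assay, with a stated time of 72 h (a lower number here means a stronger inhibitor, a higher number a weaker inhibitor), compound 3 gives only a limit, > 1000 nM. Within the data shown here, compound 1 `O=C(NCCCCc1ccccc1)c1cccc(C2SCC(=O)N2c2cccc(-c3c[nH]nn3)c2)c1` is the one member with a number: in this assay compound 1 gives 110 nM. Compound 2 `COc1ccc(OC)c(N2C(=O)CSC2c2cccc(C(=O)NCCCCc3ccccc3)c2)c1` likewise gives only a limit in this assay, > 1000 nM. Measured against compound 1, both changes at this nitrogen are clear losses: an at least 9.0-fold higher number from compound 1 to compound 2 (0.95 log units; beyond the scatter) and an at least 9.0-fold higher number from compound 1 to compound 3 (0.95 log units; beyond the scatter), each beyond the scatter. Between the two weak members nothing can be read, since a step that the two limits leave unreadable from compound 2 to compound 3; the reason is the limit of > 1000 nM in this assay, at which 2 of the 3 values shown sit.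

Compound 4 `COc1c(F)cccc1N1C(=O)CSC1c1cccc(C(=O)NCCCCc2ccccc2)c1` is the next variation at the same place: 3-fluoro-2-methoxyphenyl in place of 1,3-thiazol-2-yl on an amide-type nitrogen in a ring. Among the measured compounds shown here, the closest precedent is compound 2, which also carries a methoxy-bearing phenyl on this nitrogen and sits at the limit, so no step beyond the scatter is expected from compound 3 to compound 4, and a limit is the more likely outcome. Compound 4 is therefore estimated at 1500 nM in this assay, within 400 nM to 6000 nM. The expected step is a step that the limit leaves unreadable from compound 3 to compound 4, not readable against a limit.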

Compound 4, half-maximal inhibitory concentration: 26.2 nM
Compound 4: middle estimate off by 57-fold (1.76 log units), on the high side; measured number below the stated range.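

In this assay, a phenyl ring on the amide-type nitrogen is compatible with high activity, since 3-fluoro-2-methoxyphenyl in place of 1,3-thiazol-2-yl gives an at least 38-fold lower number from compound 3 to compound 4 (1.58 log units; beyond the scatter). A methoxy-bearing phenyl does not settle the outcome either: the change from 2,5-dimethoxyphenyl to 3-fluoro-2-methoxyphenyl gives an at least 38-fold lower number from compound 2 to compound 4 (1.58 log units; beyond the scatter), so the substituents on this phenyl matter within these compounds. The group of compound 1, with its five-membered aromatic ring with 3 hetero atoms, is also not needed for activity at this nitrogen, as the smaller group of compound 4 gives a 4.2-fold lower number from compound 1 to compound 4 (0.62 log units; beyond the scatter).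

From the compounds shown here alone, the true size of the steps from compound 2 and compound 3 remains unknown, because each starts from a limit of the assay rather than a number: the limit of > 1000 nM in this assay, at which 2 of the 4 values shown sit. The compounds shown do not separate the contributions of the fluorine and the methoxy group in compound 4, and they leave open whether a phenyl carrying an amine or a carboxylic acid would match compound 4 at 26.2 nM.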